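The source may report more compounds than this note shows. Statements on the series, on what has been measured and on what is new or still open speak of the compounds shown alone.

Measured compounds:
compound 1 `Cn1cc(C(=O)N/N=C\c2cn(Cc3ccc(Cl)cc3)c3cc(F)ccc23)c2ccccc21` — 22100 nM
compound 2 `COc1ccc(Cn2cc(/C=N\NC(=O)c3c[nH]c4ccc(Br)cc34)c3ccc(F)cc32)cc1` — 21800 nM
compound 3 `COc1ccc(Cn2cc(/C=N\NC(=O)c3c[nH]c4ccccc34)c3ccc(F)cc32)cc1` — 18400 nM

In a functional assay on PC-3 cells (Homo sapiens) for cytotoxicity (a lower number here means a stronger inhibitor, a higher number a weaker inhibitor), compound 3 gives 18400 nM. Compound 2 gives 21800 nM and compound 1 gives 22100 nM; the three numbers lie within the usual scatter of one another, so none of them can be set apart. Going by the values given here, the only single-point step among the measured compounds is a 1.2-fold lower number from compound 2 to compound 3 (0.07 log units; within the scatter), which concerns the removal of a bromo group and says nothing about the change now at hand.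

Compound 4 `COc1ccc(Cn2cc(/C=N\NC(=O)c3cn(C)c4ccccc34)c3ccc(F)cc32)cc1` differs from compound 3 by methyl in place of hydrogen on an aromatic nitrogen. Compound 1 carries the same methyl on its aromatic nitrogen, but it differs from compound 3 in more than one place, so no direct step can be read from it; what its value does show is a number within the scatter of compound 3. Among the compounds with values here, with no measured step bearing on this change, and with all three numbers sitting close together, the expectation is a step of a 1.0-fold higher number from compound 3 to compound 4 (0.01 log units; within the scatter), that is nothing beyond the scatter. Compound 4 is therefore estimated at 19000 nM, with a range from 9000 nM to 40000 nM.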

Compound 4, half-maximal inhibitory concentration: 12800 nM
The estimate for compound 4 lay 1.5-fold (0.17 log units) above the measured number; the measured number falls inside the stated range.
By their numbers in this assay, from the lowest: compounds 4, 3, 2 and 1 (each within the scatter of the next).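

Turning 1H-indol-3-yl into 1-methyl-1H-indol-3-yl gives a 1.4-fold lower number from compound 3 to compound 4 (0.16 log units; within the scatter) in this assay; so this aromatic nitrogen can carry a methyl instead of its hydrogen without the number moving beyond the scatter, a point that no earlier pair could test directly. The two other comparisons also show no separation: 1-methyl-1H-indol-3-yl in place of 5-bromo-1H-indol-3-yl gives a 1.7-fold lower number from compound 2 to compound 4 (0.23 log units; within the scatter), and methoxy in place of chloro on an aromatic carbon gives a 1.7-fold lower number from compound 1 to compound 4 (0.24 log units; within the scatter). No measurement among these compounds gives a reason for any of these numbers.

On these data alone, all four compounds sit within the scatter of their neighbours, so it remains open whether any change on this nitrogen can shift the number clearly, for instance a longer chain such as propyl, a benzyl group, or a chain ending in an amine or a carboxylic acid. As far as these compounds go, it is also open whether the methyl on this nitrogen and the bromo group would give a similar number when carried together on one compound.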